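The source may hold more compounds than are shown below. What is called first, only, known or untested is meant among the compounds shown, and "the series" means these compounds.

Measured compounds in a functional assay on PANC-1 cells (Homo sapiens) for inhibition, read by MTT assay, with a stated time of 24 h, tested at 10 uM; on this read-out lower numbers stand for less inhibition and higher numbers for more inhibition at the one concentration tested (going by the name of the read-out):
- compound 1, `CC(C)=CCC1Cc2c(OCCCNS(=O)(=O)c3ccc(Cl)cc3)cc(=O)n(CCCO)c2CC1(C)C`, gives 24.7%
- compound 2, `CC(C)=CCC1Cc2c(OCCCNS(=O)(=O)c3ccc([N+](=O)[O-])cc3)cc(=O)n(CCCO)c2CC1(C)C`, gives 47.7%
- compound 3, `CC(C)=CCC1Cc2c(OCCCNC(=O)c3ccc([N+](=O)[O-])cc3)cc(=O)n(CCCO)c2CC1(C)C`, gives 49.9%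

Compound 2 is the second highest of the three numbers. Its gap to compound 3, a number 2.2 percentage points higher from compound 2 to compound 3 (within the scatter), is within the scatter, so the two cannot be ordered; its gap to compound 1, a number 23 percentage points higher from compound 1 to compound 2 (beyond the scatter), lies beyond the scatter, as does a number 25.2 percentage points higher from compound 1 to compound 3 (beyond the scatter).

Compound 4, `CC(C)=CCC/C(C)=C/CC1Cc2c(OCCCNS(=O)(=O)c3ccc([N+](=O)[O-])cc3)cc(=O)n(CCCO)c2CC1(C)C`, differs from compound 2 as follows: 3-methylbut-2-en-1-yl in place of hydrogen on a saturated chain carbon bound to a double-bonded chain carbon. Cut one bond further out, the same difference reads 3-methylbut-2-en-1-yl to 3,7-dimethylocta-2,6-dien-1-yl.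

Within the data shown here, none of the measured steps touches this part of the molecule: all three vary only the group on the amine nitrogen, and compounds 1, 2 and 3 carry the same chain on the shared core. Among the measured compounds shown here, no measured step therefore bears on the change from compound 2 to compound 4, and there is no basis for expecting a move in either direction beyond the scatter in this assay. The expected step is a number 0.3 percentage points higher from compound 2 to compound 4 (within the scatter). Compound 4 is estimated at 48%, with a range from 28% to 68% reflecting the lack of any comparable step.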

Compound 4, a percentage reported as inhibition, at one concentration (the size of the read-out at that concentration, not a potency): 7.4%
For compound 4 the middle estimate is 40.6 percentage points above the measured one, and the stated range ends above it.
By their numbers in this assay, from the lowest: compound 4; then compound 1; then compounds 2 and 3 (each within the scatter of the next).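

In this assay, the chain on the shared core proves to be a sensitive place: adding 3-methylbut-2-en-1-yl on a saturated chain carbon bound to a double-bonded chain carbon gives a number 40.3 percentage points lower from compound 2 to compound 4 (beyond the scatter). The earlier compounds shown here all carry the same chain and differ only in the group on the amine nitrogen, so they could not show that the 3,7-dimethylocta-2,6-dien-1-yl chain costs this much inhibition with the 4-nitrophenylsulfonyl group held fixed. Nothing available accounts for the drop.

Going by these compounds, it remains open whether the loss follows the length of the chain or its double bonds; a fully saturated chain of the same length or a short ethyl group at this place would separate the two. Also open, on these data alone, is whether the step carries over to the carbonyl-linked amide of compound 3.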